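The source may hold more compounds than are shown below. What is called first, only, known or untested is meant among the compounds shown, and "the series" means these compounds.

Compound 1 `CCC1(c2ccccc2)CC(=O)C(C2CC(c3ccc(-c4ccc(Br)cc4)cc3)Cc3ccccc32)=C(O)O1` — > 10000 nM
Compound 2 `CCC1(c2ccccc2)CC(=O)C(C2CC(c3ccc(OCc4ccc(C(F)(F)F)cc4)cc3)Cc3ccccc32)=C(O)O1` — > 10000 nM

In a functional assay on HCT-15 cells (Homo sapiens) for inhibition, with a stated time of 72 h (a higher number here means a weaker inhibitor, a lower number a stronger inhibitor), compound 1 gives only a limit of the assay, > 10000 nM, and no number. Compound 2 likewise gives only a limit in this assay, > 10000 nM. Compound 2 therefore stands at the edge of what the assay can report, and the step that the two limits leave unreadable from compound 1 to compound 2 cannot be read in either direction. Compound 3 `CCC1(c2ccccc2)CC(=O)C(C2CC(c3ccc(OC)cc3)Cc3ccccc32)=C(O)O1` differs from compound 2 by hydrogen in place of 4-(trifluoromethyl)phenyl on a saturated chain carbon bound to an oxygen on an aromatic ring. Among the measured compounds shown here, the only measured step that touches this region of the molecule is the one from compound 1 to compound 2, and its size is hidden because of the limit of > 10000 nM in this assay, at which 2 of the 2 values shown sit. For the measured compounds named here, no measured step gives a direction or a size for the change to compound 3 in this assay. On this basis compound 3 is expected to remain near the limit, with the expected step that the limit leaves unreadable from compound 2 to compound 3. The estimate for compound 3 in this assay is 15000 nM, from 3000 nM to 60000 nM.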

Compound 3, half-maximal inhibitory concentration: > 10000 nM
Compound 3 ended at the assay's limit; the forecaster's own chance of this, stated with the estimate: 70%; the middle value is on the limit's open side.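

Compound 3 also gives only a limit in this assay, so no step among compound 1, compound 2 and compound 3 can be read: the limit of > 10000 nM in this assay, at which 3 of the 3 values shown sit.

The compounds shown leave open how strongly any of the three inhibits, and whether exchanging these groups changes that at all.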